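The compounds below may be only part of what the source reports. "The series", "measured", "known", "first", "only" and "open" are said of these compounds alone.

Measured so far:
Compound 1 `COc1ccc(/C=C\c2cc(OC)c(OC)c(OC)c2)cc1OCc1ccc(CN2CCCCC2C(=O)NCCNC(=O)OC(C)(C)C)cc1`: 28000 nM
Compound 2 `COc1ccc(/C=C\c2cc(OC)c(OC)c(OC)c2)cc1OCc1ccc(CNCCNC(C)=O)cc1`: 54000 nM

Both values come from an ADME assay on NCM460 cells (Homo sapiens) for cytotoxicity, read by CCK-8 assay, with a stated time of 48 h; on this read-out higher numbers stand for weaker inhibition and lower numbers for stronger inhibition. Compound 2 gives 54000 nM and compound 1 gives 28000 nM. These two numbers lie within the scatter of each other, so no order can be claimed between them.

The next entry is compound 3 `COc1ccc(/C=C\c2cc(OC)c(OC)c(OC)c2)cc1OCc1ccc(CN2CCCCC2C(=O)NCCN)cc1`. Going from compound 2, the change is 2-((2-aminoethyl)carbamoyl)piperidin-1-yl in place of (2-acetamidoethyl)amino on a saturated chain carbon bound to an aromatic carbon: 2-((2-aminoethyl)carbamoyl)piperidin-1-yl in place of (2-acetamidoethyl)amino, on a saturated chain carbon bound to an aromatic carbon.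

Going by the values given here, no measured pair differs in one place only, so the data give no direct size for such a change. Among the compounds with values here, the only guide is the close pair of values already in hand, so no step beyond the scatter is expected in this assay, and no direction can be firmly assigned.

In this assay the estimated value for compound 3 is 30000 nM, with an expected range from 10000 nM to 80000 nM. This estimate means an expected 1.8-fold lower number from compound 2 to compound 3 (0.26 log units; within the scatter).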

Compound 3, half-maximal inhibitory concentration: > 50000 nM
Compound 3: no number, only a limit; the forecaster's own chance of this, stated with the estimate: 15%; middle value at least 1.6-fold (0.22 log units) from the limit.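

In this assay compound 3 gives > 50000 nM, which is a limit of the assay and not a number. Hydrogen in place of tert-butoxycarbonyl on an amine nitrogen is the first change in one place that can be sized in this series, and it gives an at least 1.7-fold higher number from compound 1 to compound 3 (0.25 log units; that floor lies within the scatter), so this change is not shown to exceed the scatter, while the true size of the step stays open on the upper side. The step between compound 2 and compound 3 cannot be read, and the series now reaches the ceiling of the read-out once: the limit of > 50000 nM in this assay, at which 1 of the 3 values shown sits.

Still open, going by these compounds, is how far the value of compound 3 lies past its limit, and so whether the free amine truly separates from the tert-butoxycarbonyl carbamate of compound 1 in this assay. Also open, on these data alone, is whether an acetyl group, a carboxylic acid or a longer chain in place of that free amine would give a readable number and a step beyond the scatter.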